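Removing the aromatic methyl from compound 1

The compounds below may be only part of what the source reports. "The series", "measured", "known", "first", "only" and "open" are said of these compounds alone.

Compound 1 `Cc1ccc2[nH]c(-c3ccc[nH]3)c(C3CC(=O)NC3=O)c2c1` is the reference point of this set. In a functional assay on B16-F10 cells (Mus musculus) for cytotoxicity, read by MTT assay, with a stated time of 72 h (a higher number here means a weaker inhibitor, a lower number a stronger inhibitor), compound 1 gives 500 nM. Compound 2 `COc1ccc2[nH]c3c(c4c(n5cccc35)C(=O)N(C)C4=O)c2c1` gives 27000 nM in this assay, a higher number than compound 1, and the gap between the two numbers is beyond the scatter. For compound 3 `COc1ccc2[nH]c3c(c4c(c5ccnn53)C(=O)NC4=O)c2c1` this assay records "not determined" (no result reported), so no number is known for it. Within the data shown here, of the two numbers known, compound 1 holds the lower one.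

Compound 4 `O=C1CC(c2c(-c3ccc[nH]3)[nH]c3ccccc23)C(=O)N1` has not been measured. It differs from compound 1 only in one place: hydrogen in place of methyl on an aromatic carbon. The change removes a single carbon with no ring, no donor and no acceptor; otherwise the shared core of compound 1 is unchanged.

Among the measured compounds shown here, no measured pair in this set shows the effect of such a change, so the expectation rests on its small size alone. The step from compound 1 to compound 4 is expected to be small, a 1.4-fold higher number from compound 1 to compound 4 (0.15 log units; within the scatter), and not beyond the scatter in either direction. Compound 4 is therefore expected to give about 700 nM in this assay, within a range of 250 nM to 2000 nM.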

Compound 4, half-maximal inhibitory concentration: 2000 nM
For compound 4 the middle estimate is 2.9-fold (0.46 log units) below the measured one; low and high end bracket the measured number.
By their numbers in this assay, from the lowest: compound 1; then compound 4; then compound 2.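

In this assay, hydrogen in place of methyl on this aromatic carbon gives a 4.0-fold higher number from compound 1 to compound 4 (0.60 log units; beyond the scatter) and so is not a neutral swap: the position responds to the loss of a single carbon. Among these compounds, this is the first step that changes one place only, and it puts the methyl of compound 1 on the side of the lower number, though the step is modest in size. Nothing on hand accounts for the step.

With only methyl and hydrogen shown on this carbon, it remains open whether an ethyl group, a chlorine atom or a hydroxyl group there would fall on the lower or the higher side of compound 1. Also open, as far as these compounds go, is whether the same step holds when the shared core carries a change elsewhere.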